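Where a Methoxy Group Sits Shapes Cytotoxicity

This account rests on a few compounds, and the source may have more. Where it says the series, first, only, none or still open, it means among the compounds named here.

Measured compounds:
compound 1 `COc1cccc(Nc2cc(-c3ccccc3)oc(=O)c2)c1` — 0.63 uM
compound 2 `O=c1cc(Nc2ccccc2)cc(-c2ccccc2)o1` — 0.12 uM
compound 3 `COc1ccccc1Nc1cc(-c2ccccc2)oc(=O)c1` — 0.44 uM

In a functional assay on A549 cells (Homo sapiens) for cytotoxicity, read by MTT assay, with a stated time of 72 h (on this read-out higher numbers stand for an effect only at larger amounts of compound and lower numbers for an effect already at smaller amounts), compound 2 stands lowest of the three, with both other values beyond the scatter from it. Compound 1 and compound 3 each add a single methoxy to compound 2, and both additions raised the number: a 3.7-fold higher number from compound 2 to compound 3 (0.56 log units; beyond the scatter) and, read the other way, a 5.3-fold lower number from compound 1 to compound 2 (0.72 log units; beyond the scatter).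

Compound 4 `COc1ccc(Nc2cc(-c3ccccc3)oc(=O)c2)cc1` differs from compound 2 by methoxy in place of hydrogen on an aromatic carbon. The two measured methoxy additions bear directly on this change, and both were modest rises. A rise of similar size is therefore expected: a 3.8-fold higher number from compound 2 to compound 4 (0.57 log units; beyond the scatter). Compound 4 is estimated at 0.45 uM, likely between 0.15 uM and 1.4 uM.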

Compound 4, concentration for half-maximal effect: 0.093 uM
Beside the measured number, compound 4's estimate is 4.8-fold (0.68 log units) above it; measured number below the stated range.
By their numbers in this assay, from the lowest: compounds 4 and 2 (each within the scatter of the next); then compounds 3 and 1 (each within the scatter of the next).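

Methoxy in place of hydrogen, para to a large group, gives a 1.3-fold lower number from compound 2 to compound 4 (0.11 log units; within the scatter) in this assay, so at this place the added group brings no measurable change. Compound 1 and compound 3 carry the same methoxy elsewhere on that ring and both stand beyond the scatter from compound 2, so the outcome of this change depends on where it is made. Nothing available here explains this difference between places.

Going by these compounds, it remains open whether an amine, a fluorine atom or a longer chain such as butoxy would also be tolerated at this place.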